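Chloro for cyano on the aryl piperazine of a pyrrolidine amide

The compounds below may be only part of what the source reports. "The series", "measured", "known", "first", "only" and "open" are said of these compounds alone.

Measured compounds and their values:
Compound 1, `CN1CCN([C@@H]2CN[C@H](C(=O)N3CCSC3)C2)CC1`, in an assay on a cell-free system (plasma) for inhibition of Dipeptidyl peptidase 4 (Rattus norvegicus), read by fluorescence (on this read-out higher numbers stand for weaker inhibition and lower numbers for stronger inhibition), compound 1 gives 81.1 nM.
Compound 2, `O=C([C@@H]1C[C@H](N2CCN(c3ccc(Br)cc3)CC2)CN1)N1CCSC1`, in this assay compound 2 gives 9 nM.
Compound 3, `N#Cc1ccc(N2CCN([C@@H]3CN[C@H](C(=O)N4CCSC4)C3)CC2)cc1`, in this assay compound 3 gives 4.7 nM.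

Compound 3 holds the lowest of the three numbers in this assay. Its distance from compound 2 is small, a 1.9-fold lower number from compound 2 to compound 3 (0.28 log units; within the scatter), so the two cannot be ranked against each other; its distance from compound 1 is clear, a 17-fold lower number from compound 1 to compound 3 (1.24 log units; beyond the scatter). The step from compound 1 to compound 2, a 9.0-fold lower number from compound 1 to compound 2 (0.95 log units; beyond the scatter), shows that any aryl group on the ring nitrogen in place of methyl brings the number down strongly.

Compound 4, `O=C([C@@H]1C[C@H](N2CCN(c3ccc(Cl)cc3)CC2)CN1)N1CCSC1`, differs from compound 3 in one place: chloro in place of cyano on an aromatic carbon. Within the data shown here, the only measured step that bears on this is the exchange between a halogen and the cyano group, a 1.9-fold lower number from compound 2 to compound 3 (0.28 log units; within the scatter), which stayed within the scatter. Chloro is another halogen, so the step from compound 3 to compound 4 is expected to be small and, if anything, toward a slightly higher number, estimated as a 1.7-fold higher number from compound 3 to compound 4 (0.23 log units; within the scatter). Compound 4 is therefore expected to give about 8 nM in this assay, with a range from 3.5 nM to 18 nM.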

Compound 4, half-maximal inhibitory concentration: 10.3 nM
Compound 4: the middle estimate sits 1.3-fold (0.11 log units) below what was measured; measured number inside the range.
By their numbers in this assay, from the lowest: compounds 3, 2 and 4 (each within the scatter of the next, the first and the last beyond it); then compound 1.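

In this assay, this position now shows a difference that can be read: a 2.2-fold higher number from compound 3 to compound 4 (0.34 log units; beyond the scatter) is a modest step beyond the scatter, whereas the earlier exchange of bromo for cyano stayed within it. The two halogens cannot be told apart, with a 1.1-fold higher number from compound 2 to compound 4 (0.06 log units; within the scatter), and the gain from putting an aryl group on the ring nitrogen holds for a third substituted phenyl, with a 7.9-fold lower number from compound 1 to compound 4 (0.90 log units; beyond the scatter), so compounds 2, 3 and 4 all lie well below compound 1. Nothing shown here explains why nitrile and chloro can be separated at this position while bromo cannot be separated from either.

The compounds shown cover only cyano, bromo and chloro on this aromatic carbon, so a plain phenyl with only hydrogen there, or a methoxy group, an amine or a carboxylic acid, remains an open case. As far as these compounds go, it is also open whether the small step between compound 3 and compound 4 would hold with a different group on the rest of the core, since every aryl compound here shares the same amide.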